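Chain-end unsaturation and cytotoxicity in a nucleoside series

A few compounds are considered here, and "the series" means these few. Any claim that something is new, unique, unknown or untested is made for them only; others in the source may bear on it.

Compounds measured so far:
compound 1 `CCCCCc1cc2cn([C@H]3C[C@H](O)[C@@H](CO)O3)c(=O)nc2o1` — > 50000 nM
compound 2 `CCCCCCCCc1cc2cn([C@H]3C[C@H](O)[C@@H](CO)O3)c(=O)nc2o1` — > 50000 nM
compound 3 `C=CCCCCCCc1cc2cn([C@H]3C[C@H](O)[C@@H](CO)O3)c(=O)nc2o1` — > 200000 nM

In a functional assay on HEL cells (Homo sapiens) for cytotoxicity, read by microscopy (a higher number here means that more compound is tolerated, a lower number that less compound is tolerated), compound 1 gives > 50000 nM, which is a limit of the assay. In this assay compound 2 likewise gives only a limit, > 50000 nM. Compound 3 also reaches only a limit, > 200000 nM, so all three values shown are limits. Accordingly the steps a step that the two limits leave unreadable from compound 1 to compound 2, a step that the two limits leave unreadable from compound 1 to compound 3 and a step that the two limits leave unreadable from compound 2 to compound 3 cannot be sized; the set tells only that none of the three compounds is cytotoxic up to the limit at which it was tested, with the limit of > 200000 nM in this assay, at which 1 of the 3 values shown sits, and (the limit of > 50000 nM in this assay, at which 2 of the 3 values shown sit).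

Compound 4 `C#CCCCCCc1cc2cn([C@H]3C[C@H](O)[C@@H](CO)O3)c(=O)nc2o1` differs from compound 3 by ethynyl in place of allyl on a saturated chain carbon, five bonds along the chain from an aromatic carbon. Within the data shown here, the only steps that bear on this change are those among compounds 1, 2 and 3, and all are unreadable. No readable step, then, points to a direction for this assay. Compound 4 is therefore expected to show 150000 nM, between 50000 nM and 400000 nM, most probably again reported as a limit, and the estimated step of an at least 1.3-fold lower number from compound 3 to compound 4 (0.12 log units; that floor lies within the scatter) is expected to stay within the scatter.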

Compound 4, minimum cytotoxic concentration: > 200000 nM
Compound 4: a limit, no number; the forecaster's own chance of this, stated with the estimate: 85%; middle value at least 1.3-fold (0.12 log units) from the limit.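

In this assay compound 4 gives > 200000 nM, which is a limit of the assay, so its steps from compound 1, compound 2 and compound 3 cannot be read. The compounds shown leave open at what concentration, if any, each becomes cytotoxic, and whether the chain end makes any difference.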